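From Dimethylamino to Acetamido at the Assay Limit

The source may hold more compounds than are shown below. What is called first, only, known or untested is meant among the compounds shown, and "the series" means these compounds.

Values in a functional assay on B16-F10 cells (Mus musculus) for antiproliferative activity, read by CCK-8 assay, with a stated time of 48 h; a lower number here means a stronger inhibitor, a higher number a weaker inhibitor:
- compound 1 `COc1ccc(/C=C\c2cc(OC)c(OC)c(OC)c2)cc1OCc1ccc(CN2CCCC[C@@H]2C(=O)O)cc1`: > 10000 nM
- compound 2 `COc1ccc(/C=C\c2cc(OC)c(OC)c(OC)c2)cc1OCc1ccc(CNCCN(C)C)cc1`: > 10000 nM
- compound 3 `COc1ccc(/C=C\c2cc(OC)c(OC)c(OC)c2)cc1OCc1ccc(CNCCNC(C)=O)cc1`: not yet measured

Compound 2 gives no number, only the limit > 10000 nM. Compound 1 also gives only a limit, > 10000 nM. Going by the values given here, the one measured step is a step that the two limits leave unreadable from compound 1 to compound 2, so it offers no size to carry forward. The remaining evidence is the limit of > 10000 nM in this assay, at which 2 of the 2 values shown sit.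

The change to compound 3 is acetamido in place of dimethylamino on a saturated chain carbon, two bonds along the chain from an amine nitrogen. Among the compounds with values here, no measured step tests this exchange, and the data give no direction for it in this assay. The expectation rests on compound 2, whose limit is > 10000 nM. Compound 3 is therefore expected to remain in the same region, and the assay may again report only a limit. The expected step is a step that the limit leaves unreadable from compound 2 to compound 3. For compound 3 the estimated value is 12000 nM, with an expected range from 3000 nM to 50000 nM.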

Compound 3, half-maximal inhibitory concentration: 2500 nM
The estimate for compound 3 lay 4.8-fold (0.68 log units) above the measured number; measured number below the stated range.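

In this assay, acetamido in place of dimethylamino, on a saturated chain carbon, two bonds along the chain from an amine nitrogen, gives the first readable step among these compounds: an at least 4.0-fold lower number from compound 2 to compound 3 (0.60 log units; beyond the scatter). The wider exchange of 2-carboxypiperidin-1-yl for (2-acetamidoethyl)amino, on a saturated chain carbon bound to an aromatic carbon, gives a step of the same printed size: an at least 4.0-fold lower number from compound 1 to compound 3 (0.60 log units; beyond the scatter). Compound 3 is thus the only compound of the three with a number in this assay, while the step between compound 1 and compound 2 cannot be read because both give only the assay limit: the limit of > 10000 nM in this assay, at which 2 of the 3 values shown sit.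

As far as these compounds go, the real values of compound 1 and compound 2 lie beyond that limit, so the full size of both readable steps stays open. The compounds shown also leave open whether the number of compound 3 would hold with a methanesulfonamido group, a urea or a longer chain in place of the 2-acetamidoethyl group, and whether the carbonyl or the amide hydrogen of acetamido matters more.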